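Oral exposure in a spiro-linked nitrothiazinone series

A few compounds are considered here, and "the series" means these few. Any claim that something is new, unique, unknown or untested is made for them only; others in the source may bear on it.

Compound 1 `O=c1nc(N2CCN(CC3CCCCC3)CC2)sc2c([N+](=O)[O-])cc(C(F)(F)F)cc12` and compound 2 `CC(c1ccc(C(F)(F)F)cc1)N1CC2(CCN(c3nc(=O)c4cc(C(F)(F)F)cc([N+](=O)[O-])c4s3)CC2)C1` were both run in an ADME assay on the whole organism (Mus musculus, strain BALB/c) for pharmacokinetics, read by HPLC, with a stated time of 24 h, at a dose of 12.5 mg/kg by the oral route; on this read-out higher numbers stand for higher exposure at the dose given and lower numbers for lower exposure. In this assay compound 1 gives 1610 nM, and compound 2 gives 2160 nM; the two numbers sit within the scatter of each other, so no order is read between them. Compound 3 `CC(c1cc(F)cc(F)c1)N1CC2(CCN(c3nc(=O)c4cc(C(F)(F)F)cc([N+](=O)[O-])c4s3)CC2)C1` is not yet measured. It differs from compound 2 by 3,5-difluorophenyl in place of 4-(trifluoromethyl)phenyl on a saturated chain carbon bound to an amine nitrogen in a ring and a saturated chain carbon. Among the compounds with values here, with no measured step across such a change, the expected step in this assay from compound 2 to compound 3 is a 1.2-fold lower number from compound 2 to compound 3 (0.08 log units; within the scatter), not beyond the scatter. For compound 3 the estimate in this assay is 1800 nM, with a range from 700 nM to 4500 nM.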

Compound 3, maximal plasma concentration: 529 nM
Compound 3: the middle estimate sits 3.4-fold (0.53 log units) above what was measured, and the stated range ends above it.
By their numbers in this assay, from the lowest: compound 3; then compounds 1 and 2 (each within the scatter of the next).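

In this assay the aryl group on a saturated chain carbon bound to an amine nitrogen in a ring and a saturated chain carbon is not a silent place: 3,5-difluorophenyl in place of 4-(trifluoromethyl)phenyl gives a 4.1-fold lower number from compound 2 to compound 3 (0.61 log units; beyond the scatter), a modest step. Within the data shown here, this is the first single change to move oral exposure beyond the scatter. Nothing on hand bears on what lies behind this step.

The compounds shown leave open whether the step follows the loss of trifluoromethyl or the arrival of the two fluorines. As far as these compounds go, how a plain phenyl or a pyridyl group would read at this place also remains open.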